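The source may report more compounds than this note shows. Statements on the series, on what has been measured and on what is new or still open speak of the compounds shown alone.

Three compounds have been measured in a functional assay on the whole organism for inhibition, with Rattus norvegicus as the target, read by ELISA, with stated times of 30 min and 6 h, at a dose of 30 mg/kg by the oral route; a lower number here means less inhibition, a higher number more inhibition at the dose given (going by the name of the read-out):

Compound 1 `N=c1sc(=S)[nH]c2c1cc(-c1ccc(Cl)cc1)n2-c1ccccc1` gives 2% in this assay.
Compound 2 `N=c1sc(=S)[nH]c2c1cc(-c1ccc(Br)cc1)n2-c1ccccc1` gives 44% in this assay.
Compound 3 `CCSc1nc2c(cc(-c3ccccc3)n2-c2ccccc2)c(=N)s1` gives 0% in this assay.

Compound 3 holds the lowest of the three numbers. Its gap to compound 1 lies within the usual scatter, so no order between those two can be read, while compound 2 stands well beyond both. Among the measured compounds shown here, the one step between measured compounds that differ in a single place, a number 42 percentage points higher from compound 1 to compound 2 (beyond the scatter), shows that the read-out can move a long way with a small change on the aromatic ring attached to the shared core. That step, however, concerns a different change and gives no direct guide to the one at hand.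

Compound 4 `CCSc1nc2c(cc(-c3ccc(C)cc3)n2-c2ccccc2)c(=N)s1` differs from compound 3 by methyl in place of hydrogen on an aromatic carbon. For the measured compounds named here, no measured pair shows a methyl replacing a hydrogen, so the expectation rests only on compound 3 sitting at the bottom of the read-out, where a move downward is not possible. The step is expected to be small, a number 6 percentage points higher from compound 3 to compound 4 (within the scatter), within the scatter. Compound 4 is therefore estimated to give 6% in this assay, somewhere between 0% and 25%.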

Compound 4, a percentage reported as inhibition, in the whole organism at one dose (the size of the read-out at that dose, not a potency): 0%
Compound 4: the middle estimate sits 6 percentage points above what was measured; low and high end bracket the measured number.
By their numbers in this assay, from the lowest: compounds 3, 4 and 1 (each within the scatter of the next); then compound 2.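

The change from phenyl to 4-methylphenyl, a methyl in place of hydrogen para to a large group, gives no change at the digits printed from compound 3 to compound 4 (within the scatter) in this assay. On this core, then, a single methyl at this place does not lift the number off the bottom of the read-out. Compound 3 already stands at that bottom, so a fall could not appear in this pair, and the result says nothing about whether methyl could lower the inhibition from a higher starting point. Nothing measured here offers an explanation for this result.

As far as these compounds go, it remains open whether an amine, a carboxylic acid or a longer chain at this same place would raise the number. The same methyl on the core of compound 1 or compound 2 is also untested by these compounds, and there a fall could be seen.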